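A few compounds are considered here, and "the series" means these few. Any claim that something is new, unique, unknown or untested is made for them only; others in the source may bear on it.

Measured so far in a functional assay on a cell-free system (Platelet, plasma, Oryctolagus cuniculus) for inhibition, with a stated time of 5 min, at 37 degrees C; on this read-out lower numbers stand for stronger inhibition and higher numbers for weaker inhibition:
- compound 1 `Cc1nc(C)c(C(=O)Oc2ccccc2/C=C/C(=O)O)nc1C`: 9600 nM
- compound 2 `COc1ccc(/C=C/C(=O)O)c(OC(=O)c2nc(C)c(C)nc2C)c1`: 134000 nM

Compound 1, at 9600 nM, holds the lower of the two numbers and so shows the stronger inhibition. Among the measured compounds shown here, its only measured neighbour is compound 2, which makes for a thin basis for any forecast.

Compound 3 `COc1ccc(OC(=O)c2nc(C)c(C)nc2C)c(/C=C/C(=O)O)c1` has not yet been measured. It departs from compound 1 by one change: methoxy in place of hydrogen on an aromatic carbon. The methoxy stands on an aromatic carbon meta to a 2-carboxyethenyl group and para to a large group.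

For the measured compounds named here, one measured step bears on this: a 14-fold higher number from compound 1 to compound 2 (1.14 log units; beyond the scatter). It is the same exchange of hydrogen for methoxy, made on a different aromatic carbon, and it is large. No measurement covers the carbon used in compound 3, so the step from compound 2 serves only as a loose guide. A step in the same direction is expected in this assay, but a smaller one, and it may not clear the scatter. The expected step is a 3.1-fold higher number from compound 1 to compound 3 (0.49 log units; beyond the scatter). For compound 3 the estimated value is 30000 nM, with an expected range of 8000 nM to 120000 nM.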

Compound 3, half-maximal inhibitory concentration: 49000 nM
The estimate for compound 3 lay 1.6-fold (0.21 log units) below the measured number; the measured number falls inside the stated range.
By their numbers in this assay, from the lowest: compound 1; then compound 3; then compound 2.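

In this assay, methoxy in place of hydrogen on the aromatic carbon meta to a 2-carboxyethenyl group and para to a large group gives a 5.1-fold higher number from compound 1 to compound 3 (0.71 log units; beyond the scatter), so the exchange raises the number at this position too. The same exchange on a different aromatic carbon gives a 14-fold higher number from compound 1 to compound 2 (1.14 log units; beyond the scatter), a large step where this one is modest, so across the two carbons shown the direction holds while the size of the step differs with the carbon that carries the methoxy. No measurement on hand accounts for this difference between the two carbons.

On these data alone, whether a hydroxyl, a fluorine or an ethoxy on this same carbon would give a step of similar size remains open, as does the outcome for methoxy on the other free aromatic carbons of the shared core. As far as these compounds go, it is also open whether the exchange would have the same effect if an amide stood in place of the carboxylic acid at the end of the 2-carboxyethenyl group.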